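The source may report more compounds than this note shows. Statements on the series, on what has been measured and on what is new or still open speak of the compounds shown alone.

The measured compounds so far:
compound 1 `Cc1ccnc(-c2cc3n(n2)CCCC3)c1` gives 3080 nM
compound 2 `Clc1ccc(-c2cc3n(n2)CCCC3)nc1` gives 669 nM
compound 3 `N#Cc1cccnc1NC(=O)c1cc2n(n1)CCCC2` gives "not active" (no number reported)

In a functional assay on HEK293 cells for negative allosteric modulation of metabotropic glutamate receptor 5 (Rattus norvegicus), read by FLIPR and calcium flux, with a stated time of 170 s (on this read-out higher numbers stand for weaker inhibition and lower numbers for stronger inhibition), compound 1 gives 3080 nM and compound 2 gives 669 nM. Compound 3, built with an amide link rather than a direct ring-to-ring bond, stands apart: in this assay compound 3 is reported as "not active" (no number reported), so there is no number to place it next to the other two. Compound 4 `COc1cccnc1NC(=O)c1cc2n(n1)CCCC2` has not been tested yet. It differs from compound 3 in one respect: methoxy in place of cyano on an aromatic carbon. Since compound 3 gave no number, no step for this change can be drawn, and nothing shown points to a gain beyond the scatter. Compound 4 is therefore estimated at 8000 nM, within a range of 1500 nM to 40000 nM, with a real chance that it too returns no number.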

Compound 4, half-maximal inhibitory concentration: "not active" (no number reported)
Compound 4 has no reported number here; no gap can be computed for the estimate.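

Compound 3 and compound 4 both lack a number, so no step can be read for replacing cyano with methoxy, and no evidence bears on this result. On these data alone, how far compound 3 and compound 4 lie from measurable inhibition remains open.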